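This account rests on a few compounds, and the source may have more. Where it says the series, first, only, none or still open, it means among the compounds named here.

Measured so far:
compound 1 `Cc1ccc(C2=NN(C3=NC(c4ccccc4)CS3)C(c3ccc4ccccc4c3)C2)cc1` — 14700 nM in a functional assay on HepG2 cells (Homo sapiens) for inhibition, read by CCK-8 assay, with a stated time of 48 h; on this read-out higher numbers stand for weaker inhibition and lower numbers for stronger inhibition
compound 2 `Cc1ccc(C2=NN(C3=NC(=O)CS3)C(c3ccc4ccccc4c3)C2)cc1` — 12700 nM in this assay

Of these two numbers in this assay, compound 1 gives the higher one, but the step of a 1.2-fold lower number from compound 1 to compound 2 (0.06 log units; within the scatter) is within the scatter, so the two compounds cannot be told apart on this read-out. That step swaps the group on the amine nitrogen of the shared core and leaves the rest untouched.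

Compound 3 `Brc1ccc(C2=NN(C3=NC(c4ccccc4)CS3)C(c3ccc4ccccc4c3)C2)cc1` differs from compound 1 at another place: bromo in place of methyl on an aromatic carbon, that is, 4-methylphenyl becomes 4-bromophenyl, on an aromatic carbon of a six-membered aromatic ring of carbon only, para to a large group. For the measured compounds named here, no measured step touches this ring, so nothing here shows how it responds to such a change. Going by the values given here, the only measured step, elsewhere on the core, was within the scatter. Compound 3 is therefore expected to give about 14000 nM, between 5000 nM and 40000 nM, an estimated step of a 1.1-fold lower number from compound 1 to compound 3 (0.02 log units; within the scatter) that is not expected to exceed the scatter.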

Compound 3, half-maximal inhibitory concentration: 20300 nM
Estimate against measurement, compound 3: 1.5-fold (0.16 log units) below; measured number inside the range.
By their numbers in this assay, from the lowest: compounds 2, 1 and 3 (each within the scatter of the next).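

Swapping methyl for bromo on this aromatic carbon, para to a large group, is the first measured change on this ring. In this assay, the change from 4-methylphenyl to 4-bromophenyl gives a 1.4-fold higher number from compound 1 to compound 3 (0.14 log units; within the scatter), so the two compounds cannot be told apart, and this one swap gives no sign that the read-out depends on which of these two groups sits here. No measurement offered here accounts for this result.

From the compounds shown here alone, with only methyl and bromo at this place, it remains open whether a quite different group, such as an amine, a carboxylic acid or a longer chain, would move the number beyond the scatter. Going by these compounds, it is also open whether bromo would behave the same way on the core of compound 2, which carries a different group on the ring nitrogen.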